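The source may hold more compounds than are shown below. What is called first, only, known or untested is meant among the compounds shown, and "the series" means these compounds.

Measured compounds:
Compound 1 `CNC(=O)[C@@]12C[C@@H]1[C@@H](n1cnc3c(NC)nc(C#Cc4ccccc4OC)nc31)[C@H](O)[C@@H]2O` gives 0.77 nM in an assay on CHO cells for displacement of a labelled ligand from adenosine receptor A3 (Homo sapiens), read by scintillation counting, with a stated time of 60 min; on this read-out lower numbers stand for stronger inhibition and higher numbers for weaker inhibition.
Compound 2 `CNC(=O)[C@@]12C[C@@H]1[C@@H](n1cnc3c(NC)nc(C#Cc4cccc(C(F)(F)F)c4)nc31)[C@H](O)[C@@H]2O` gives 3.39 nM in this assay.

Among the measured compounds shown here, of these two numbers, compound 2 stands at the highest; its only neighbour is compound 1, separated from it by a 4.4-fold higher number from compound 1 to compound 2 (0.64 log units; beyond the scatter), a modest step but one beyond the scatter. Compound 3 `CNC(=O)[C@@]12C[C@@H]1[C@@H](n1cnc3c(NC)nc(C#Cc4ccc(CO)cc4)nc31)[C@H](O)[C@@H]2O` has not yet been measured in this assay. It differs from compound 2 in one place: 4-(hydroxymethyl)phenyl in place of 3-(trifluoromethyl)phenyl on a triple-bonded carbon. For the measured compounds named here, the single measured step that bears on this position is a 4.4-fold higher number from compound 1 to compound 2 (0.64 log units; beyond the scatter), an exchange of one aryl group for another on the same triple-bonded carbon, and neither of those aryl groups carried a hydroxymethyl group. Going by the values given here, no measured compound shows what a hydroxymethyl group at this place does, so the direction of the coming step cannot be read from the data; the one known step only suggests that a shift of similar, modest size is the most that should be expected. Compound 3 is therefore estimated to give about 2.5 nM in this assay, within a range from 0.6 nM to 10 nM, which amounts to an expected 1.4-fold lower number from compound 2 to compound 3 (0.13 log units; within the scatter).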

Compound 3, inhibition constant: 2.16 nM
Compound 3: the middle estimate sits 1.2-fold (0.06 log units) above what was measured; measured number inside the range.
By their numbers in this assay, from the lowest: compound 1; then compounds 3 and 2 (each within the scatter of the next).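

Exchanging 3-(trifluoromethyl)phenyl for 4-(hydroxymethyl)phenyl on the triple-bonded carbon gives a 1.6-fold lower number from compound 2 to compound 3 (0.20 log units; within the scatter) in this assay and so shows that this position accepts an aryl group with a hydrogen-bond donor and acceptor, where the group that leaves has neither, without a change that can be told from scatter. Among the compounds shown here, the 2-methoxyphenyl group of compound 1 still stands apart, since its exchange for 4-(hydroxymethyl)phenyl gives a 2.8-fold higher number from compound 1 to compound 3 (0.45 log units; beyond the scatter) and compound 1 keeps the lowest number of the three, with a step to compound 3 that is modest, like the one to compound 2. Nothing at hand accounts for either step.

Going by these compounds, compound 2 and compound 3 differ both in the group on the phenyl ring and in where it sits, so what hydroxymethyl contributes apart from its place remains open, as does whether the lower number of compound 1 belongs to the methoxy group or to its place. On these data alone, how an amine or a carboxylic acid in place of the hydroxymethyl group, or a longer chain ending in a hydroxyl, would fare at this position is also open.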